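A few compounds are considered here, and "the series" means these few. Any claim that something is new, unique, unknown or untested is made for them only; others in the source may bear on it.

Of the compounds shown here, three built on one shared core have been measured in an assay on MDA-MB-231 cells for displacement of a labelled ligand from C-X-C chemokine receptor type 4 (Homo sapiens), read by fluorescence and microscopy, with stated times of 10 min and 30 min; on this read-out lower numbers stand for an effect already at smaller amounts and higher numbers for an effect only at larger amounts of compound. Compound 1 `Cc1ccccc1C(=O)NCc1ccc(CNS(=O)(=O)c2cccc(Cl)c2)cc1` gives 100 nM, and compound 3 `O=C(NCc1ccc(CNS(=O)(=O)c2cccc(Cl)c2)cc1)c1cccnc1` gives 100 nM; on these numbers compound 1 and compound 3 stand together as the lowest of the three, while compound 2 `O=C(NCc1ccc(CNS(=O)(=O)c2cccc3ccccc23)cc1)c1cccnc1` gives 1000 nM, the highest. The step of no change at the digits printed from compound 1 to compound 3 (within the scatter) shows that exchanging the group on the carbonyl carbon left the number where it was, whereas a 10-fold lower number from compound 2 to compound 3 (1.00 log units; beyond the scatter) shows that the group on the sulfonyl sulfur can move it considerably. Compound 4 `Cc1ccccc1C(=O)NCc1ccc(CNS(=O)(=O)c2ccccc2C)cc1` differs from compound 1 by 2-methylphenyl in place of 3-chlorophenyl on a sulfonyl sulfur. Within the data shown here, only one measured step touches the sulfonyl sulfur, and it was sizeable, so a moderate rise with wide uncertainty is expected. Compound 4 is estimated at 250 nM, within 60 nM to 1000 nM, a step of a 2.5-fold higher number from compound 1 to compound 4 (0.40 log units; beyond the scatter).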

Compound 4, effective concentration (reported as EC, without a stated level of effect): 10 nM
Compound 4: middle estimate off by 25-fold (1.40 log units), on the high side; measured number outside the range, below it.
By their numbers in this assay, from the lowest: compound 4; then compounds 1 and 3 (each within the scatter of the next); then compound 2.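

In this assay, 2-methylphenyl on the sulfonyl sulfur gives a 10-fold lower number from compound 1 to compound 4 (1.00 log units; beyond the scatter), so 3-chlorophenyl, the group with the lower number in a 10-fold lower number from compound 2 to compound 3 (1.00 log units; beyond the scatter), does not mark the lowest number reachable at this position. The two groups have the same heavy-atom count and the same hydrogen-bond counts, yet the number still moves beyond the scatter. No measurement shown here explains this step. From the compounds shown here alone, it remains open whether 2-methylphenyl would give a similar step in compound 3, which carries pyridin-3-yl on the carbonyl carbon. Going by these compounds, the effect of a methoxyphenyl or aminophenyl group on the sulfonyl sulfur also remains open.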